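From Amide to Urea: An Estimate for Compound 4

The compounds below may be only part of what the source reports. "The series", "measured", "known", "first", "only" and "open" are said of these compounds alone.

Compound 2 `COc1cc(-c2nn(-c3cccc(NC(=O)c4cccc(C(F)(F)F)c4)c3)cc2-c2ccncc2)ccc1Cl` was tested in a functional assay on NCI-H322M cells (Homo sapiens) for inhibition, read by sulforhodamine B assay, with a stated time of 48 h; on this read-out lower numbers stand for stronger inhibition of growth and higher numbers for weaker inhibition of growth. In that setting compound 2 reaches only the limit of > 50000 nM, which is a limit of the measurement and not a number. Compound 3 `O=C(Nc1cccc(-n2cc(-c3ccncc3)c(-c3ccc(Cl)c(O)c3)n2)c1)Nc1ccc(Cl)c(Cl)c1` likewise stops at the limit of > 32500 nM in this assay. Compound 1 `COc1cc(-c2nn(-c3cccc(NC(=O)Nc4cc(C(F)(F)F)cc(C(F)(F)F)c4)c3)cc2-c2ccncc2)ccc1Cl` gives 3000 nM in this assay. Compound 4 `COc1cc(-c2nn(-c3cccc(NC(=O)Nc4cccc(C(F)(F)F)c4)c3)cc2-c2ccncc2)ccc1Cl` awaits measurement. Relative to compound 2 it carries (3-(trifluoromethyl)phenyl)amino in place of 3-(trifluoromethyl)phenyl on a carbonyl carbon. Since compound 1 gives 3000 nM in this assay with the same urea, the step from compound 2 to compound 4 is expected to run toward stronger inhibition, estimated as an at least 6.2-fold lower number from compound 2 to compound 4 (0.79 log units; beyond the scatter). Compound 4 is therefore estimated at 8000 nM, with an expected range from 2000 nM to 50000 nM.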

Compound 4, concentration for total growth inhibition: 4730 nM
The estimate for compound 4 lay 1.7-fold (0.23 log units) above the measured number; the measured number falls inside the stated range.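

In this assay, (3-(trifluoromethyl)phenyl)amino in place of 3-(trifluoromethyl)phenyl on a carbonyl carbon gives an at least 10-fold lower number from compound 2 to compound 4 (1.02 log units; beyond the scatter) as a direct reading of this change in one matched pair. With a 1.6-fold higher number from compound 1 to compound 4 (0.20 log units; within the scatter) as the reading for hydrogen in place of trifluoromethyl on an aromatic carbon, the urea keeps its level of inhibition without the second trifluoromethyl. The first step has only a bound, and compound 2 stands at a limit and not a number: the limit of > 50000 nM in this assay, at which 1 of the 4 values shown sits. The compounds shown leave open whether a carbamate oxygen or a methylene in place of the new amino nitrogen would hold this level.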